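The source may hold more compounds than are shown below. What is called first, only, known or untested is meant among the compounds shown, and "the series" means these compounds.

Within the data shown here, compound 2 `NC1CCC(Nc2nc(NCc3ccc(-c4cccs4)nc3)c3ncn(C4CCCC4)c3n2)CC1` gives 97 nM in a functional assay on HCT-116 cells (Homo sapiens) for inhibition, with a stated time of 72 h (on this read-out lower numbers stand for stronger inhibition and higher numbers for weaker inhibition), the lowest of the two numbers so far; compound 1 `NC1CCC(Nc2nc(NCc3ccc(-c4ccccc4)cc3)c3ncn(C4CCCC4)c3n2)CC1` gives 745 nM, and a 7.7-fold lower number from compound 1 to compound 2 (0.89 log units; beyond the scatter). Compound 3 `NC1CCC(Nc2nc(NCc3cc(Cl)ccc3O)c3ncn(C4CCCC4)c3n2)CC1` differs from compound 2 by 5-chloro-2-hydroxyphenyl in place of 6-(thiophen-2-yl)pyridin-3-yl on a saturated chain carbon bound to a nitrogen on an aromatic ring. Among the measured compounds shown here, the only measured step bearing on this place, also a swap of one aromatic group for another there, was modest, so a step of similar size is plausible, but its direction cannot be read from one step. The expected step is a 4.1-fold higher number from compound 2 to compound 3 (0.62 log units; beyond the scatter), a weakening beyond the scatter. Compound 3 is thus estimated at 400 nM, in a range from 100 nM to 2000 nM.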

Compound 3, half-maximal inhibitory concentration: 350 nM
Compound 3: the middle estimate sits 1.1-fold (0.06 log units) above what was measured; measured number inside the range.
By their numbers in this assay, from the lowest: compound 2; then compound 3; then compound 1.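

Until now this place had carried only groups with two aromatic rings, and the single-ring 5-chloro-2-hydroxyphenyl shows that one ring still gives a measurable number. That group lands in the middle, with a 3.6-fold higher number from compound 2 to compound 3 (0.56 log units; beyond the scatter) but a 2.1-fold lower number from compound 1 to compound 3 (0.33 log units; beyond the scatter) in the other direction, so the ring count alone does not set the order of these three compounds. Nothing measured here says why the numbers fall this way. Still open, as far as these compounds go, is what the chlorine and the hydroxyl each contribute, which a plain phenyl or a 3-chlorophenyl at this place would help to separate.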